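The source may hold more compounds than are shown below. What is called first, only, known or untested is meant among the compounds shown, and "the series" means these compounds.

Compound 1 `Nc1nc(Cl)c2ncn(Cc3ccccc3CCl)c2n1` is the starting point of this step. In a functional assay on K562 cells (Homo sapiens) for cytotoxicity, read by sulforhodamine B assay, with a stated time of 48 h (a lower number here means that less compound is tolerated, a higher number that more compound is tolerated), compound 1 gives only a limit of the assay, > 100000 nM. Compound 1 thus stands at the upper edge of the numbers shown, at the limit of > 100000 nM in this assay, at which 1 of the 2 values shown sits. For the measured compounds named here, compound 2 `ClCc1cccc(Cn2cnc3nc(Cl)nc(Cl)c32)c1` carries a different substitution pattern on the shared core, and in this assay compound 2 gives 5240 nM; no step links compound 2 to compound 1, and the two values show only that compound 2 sits at a measured number where compound 1 does not.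

Compound 3 `ClCc1ccccc1Cn1cnc2c(Cl)ncnc21` is not yet measured. It differs from compound 1 by hydrogen in place of amino on an aromatic carbon. With the known value of compound 1 being a limit, nothing pins the size of this step, and the removal of a donor and an acceptor is expected to move the number little, or downward into the measurable range. The expected step is an at least 2.0-fold lower number from compound 1 to compound 3 (0.30 log units; that floor lies within the scatter). Compound 3 is estimated at 50000 nM, with a range from 10000 nM to 200000 nM, and a fair chance that again only a limit is reported.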

Compound 3, concentration lethal to 50% of the cells: > 100000 nM
Compound 3 ended at the assay's limit; the forecaster's own chance of this, stated with the estimate: 45%; middle value at least 2.0-fold (0.30 log units) from the limit.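

In this assay compound 3 gives > 100000 nM, which is a limit of the assay. Compound 1 also stands at a limit, and no step from compound 1 to compound 3 can be read: the limit of > 100000 nM in this assay, at which 2 of the 3 values shown sit.

From the compounds shown here alone, whether hydrogen in place of amino on that aromatic carbon changes the number at all, and in which direction, stays open.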